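The source may hold more compounds than are shown below. What is called first, only, known or untested is meant among the compounds shown, and "the series" means these compounds.

Among the measured compounds shown here, in a functional assay on PC-3 cells (Homo sapiens) for antiproliferative activity, read by MTT assay, with a stated time of 72 h (a lower number here means a stronger inhibitor, a higher number a weaker inhibitor), compound 1 (`CCCCCCCCCCCNC[C@@H]1OC[C@H](N)[C@@H]1O`) gives 3330 nM and stands as the lower of the two numbers so far, while its stereoisomer compound 2 (`CCCCCCCCCCCNC[C@@H]1OC[C@H](N)[C@H]1O`) gives 10000 nM. That single step, a 3.0-fold higher number from compound 1 to compound 2 (0.48 log units; beyond the scatter), comes with the fact that compounds 1 and 2 differ only in the configuration as drawn and leaves the chain untouched, so it offers only a rough guide to size. Compound 3 (`CCCCCCCCCCCCCCNC[C@@H]1OC[C@H](N)[C@@H]1O`) differs from compound 1 by propyl in place of hydrogen on a saturated chain carbon, ten or more bonds along the chain from an amine nitrogen: propyl in place of hydrogen on a saturated chain carbon. A modest move toward a lower number in this assay is expected, and the estimated step is a 1.3-fold lower number from compound 1 to compound 3 (0.12 log units; within the scatter). For compound 3 the expected value is 2500 nM, with an estimated range from 900 nM to 7000 nM.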

Compound 3, half-maximal inhibitory concentration: 1200 nM
The estimate for compound 3 lay 2.1-fold (0.32 log units) above the measured number; low and high end bracket the measured number.
By their numbers in this assay, from the lowest: compound 3; then compound 1; then compound 2.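

In this assay, propyl in place of hydrogen on a saturated chain carbon, ten or more bonds along the chain from an amine nitrogen, gives a 2.8-fold lower number from compound 1 to compound 3 (0.44 log units; beyond the scatter) with the core untouched. Among the compounds shown here, the earlier compounds varied only configuration, so this is the first sign that the length of the chain itself moves the number beyond the scatter. Nothing measured here explains this step.

Going by these compounds, whether a longer chain or a phenyl at the chain end would go further remains open. So does whether the same change would hold on compound 2.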